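The source may hold more compounds than are shown below. What is called first, only, known or untested is meant among the compounds shown, and "the series" means these compounds.

Compound 3 `CCCC(=O)N1CC2CC(C1)N2` is the point of departure. In an assay on SH-EP1 cells for agonist activity at Neuronal acetylcholine receptor; alpha4/beta2 (Homo sapiens), read by FLIPR and calcium flux (a lower number here means a smaller maximal response, a higher number a larger maximal response), compound 3 gives 110%, level at the digits shown with compound 2 `CCC(=O)N1CC2CC(C1)N2`, which gives 110%; together the two stand highest of the three numbers, above compound 1 `CC(=O)N1CC2CC(C1)N2`, which gives 95%. Compound 4 `CC(C)C(=O)N1CC2CC(C1)N2` is not yet measured; it differs from compound 3 by isopropyl in place of propyl on a carbonyl carbon. The measured steps that bear on this are a number 15 percentage points higher from compound 1 to compound 2 (beyond the scatter) and a number 15 percentage points higher from compound 1 to compound 3 (beyond the scatter), both modest, and the no change at the digits printed from compound 2 to compound 3 (within the scatter). Because the no change at the digits printed from compound 2 to compound 3 (within the scatter) lies within the scatter, a step of no change at the digits printed from compound 3 to compound 4 (within the scatter) is expected, that is none beyond the scatter. Compound 4 is accordingly estimated at 110%, within 95% to 125%.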

Compound 4, largest response reached (Emax), in percent of the reference or control that the assay uses: 71%
The estimate for compound 4 lay 39 percentage points above the measured number, and the stated range ends above it.
By their numbers in this assay, from the lowest: compound 4; then compound 1; then compounds 2 and 3 (each within the scatter of the next).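

With the same carbons joined differently, isopropyl in place of propyl on a carbonyl carbon gives a number 39 percentage points lower from compound 3 to compound 4 (beyond the scatter) in this assay, so at this position how the chain is joined counts, whereas lengthening it gave no change at the digits printed from compound 2 to compound 3 (within the scatter) and no more. A methyl in place of hydrogen on the saturated chain carbon bound to the carbonyl carbon gives a number 39 percentage points lower from compound 2 to compound 4 (beyond the scatter) here. Isopropyl in place of methyl gives a number 24 percentage points lower from compound 1 to compound 4 (beyond the scatter) and so reverses the gain seen with the unbranched chains. Nothing measured here accounts for this drop. On these data alone, whether a tert-butyl or a cyclopropyl on the same carbonyl carbon would lower the response as well stays open, and so does whether a longer branched chain would.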